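This account rests on a few compounds, and the source may have more. Where it says the series, first, only, none or still open, it means among the compounds named here.

Measured compounds:
compound 1, `O=C(COc1ccc2cc(/C=C3/SC(=O)NC3=O)ccc2c1)Nc1ccccc1`: 2100 nM in an assay on isolated protein for inhibition of histone deacetylase 4 (Homo sapiens), with a stated time of 1 h; a lower number here means a stronger inhibitor, a higher number a weaker inhibitor
compound 2, `O=C(COc1ccc2cc(/C=C3/SC(=O)NC3=O)ccc2c1)Nc1ccc(Cl)c(Cl)c1`: 5500 nM in this assay

Compound 1 gives the lowest of the two numbers in this assay. Compound 3, `Cc1ccc(NC(=O)COc2ccc3cc(/C=C4/SC(=O)NC4=O)ccc3c2)cc1Cl`, differs from it by 3-chloro-4-methylphenyl in place of phenyl on an amide-type nitrogen. Among the measured compounds shown here, the one step that bears on this change is a 2.6-fold higher number from compound 1 to compound 2 (0.42 log units; beyond the scatter), in which a chlorine-bearing phenyl also replaced the phenyl. A similar modest rise beyond the scatter is therefore expected, and compound 3 is estimated to give 4000 nM in this assay, within a range of 2000 nM to 8000 nM. This expectation amounts to a 1.9-fold higher number from compound 1 to compound 3 (0.28 log units; within the scatter).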

Compound 3, half-maximal inhibitory concentration: 1100 nM
For compound 3 the middle estimate is 3.6-fold (0.56 log units) above the measured one; measured number below the stated range.
By their numbers in this assay, from the lowest: compounds 3 and 1 (each within the scatter of the next); then compound 2.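

Placing 3-chloro-4-methylphenyl on the amide-type nitrogen gives a 1.9-fold lower number from compound 1 to compound 3 (0.28 log units; within the scatter) in this assay so a chlorine-bearing phenyl does not always bring the rise seen with 3,4-dichlorophenyl. Methyl in place of chloro on an aromatic carbon gives a 5.0-fold lower number from compound 2 to compound 3 (0.70 log units; beyond the scatter) so the number responds to that single substituent. No measurement offers an explanation for this. The compounds shown leave open what a lone chloro or a lone methyl on the phenyl would give. They also leave open how an amine or a carboxylic acid would behave there.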